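This account rests on a few compounds, and the source may have more. Where it says the series, first, only, none or still open, it means among the compounds named here.

Of the compounds shown here, three have been measured in a physicochemical assay for solubility, in phosphate buffer, at pH 7.4; on this read-out lower numbers stand for lower solubility and higher numbers for higher solubility. Compound 1 `OCC1CCN(c2nccnc2OC2CN(c3nc4ccccc4s3)C2)CC1` gives 31000 nM, compound 2 `OCC1CCN(c2nccnc2OC2CN(c3cnc4ccccc4n3)C2)CC1` gives 500000 nM, and compound 3 `NC(=O)C1CCN(c2nccnc2OC2CN(c3ccc4ccccc4n3)C2)CC1` gives 14000 nM. Compound 3 therefore stands lowest of the three, with compound 1 its nearest neighbour at a higher number and compound 2 far higher still, both gaps beyond the usual scatter.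

Compound 4 `COC(=O)N1CCC(c2nccnc2OC2CN(c3ccc4ccccc4n3)C2)CC1` is the next candidate, and it differs from compound 3 in one place: 1-(methoxycarbonyl)piperidin-4-yl in place of 4-carbamoylpiperidin-1-yl on an aromatic carbon. Going by the values given here, no measured pair yet shows such a change, so the expectation rests on compound 3 alone. The step from compound 3 to compound 4 is expected to be modest and downward, a 2.8-fold lower number from compound 3 to compound 4 (0.45 log units; beyond the scatter), because compound 3 already sits at 14000 nM. Compound 4 is estimated to reach 5000 nM in this assay, within a range of 1500 nM to 20000 nM.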

Compound 4, solubility: 138000 nM
The estimate for compound 4 lay 28-fold (1.44 log units) below the measured number; the measured number lies above the stated range.
By their numbers in this assay, from the lowest: compound 3; then compound 1; then compound 4; then compound 2.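

In this assay there is a 9.9-fold higher number from compound 3 to compound 4 (0.99 log units; beyond the scatter) when 1-(methoxycarbonyl)piperidin-4-yl replaces 4-carbamoylpiperidin-1-yl on this aromatic carbon, so the read-out clearly depends on the group placed here. The change also loses the hydrogen-bond donor and moves the piperidine's point of attachment from nitrogen to carbon, so several features shift at once. Nothing measured here explains the rise.

From the compounds shown here alone, it remains open whether the methoxycarbonyl group or the changed attachment matters more. Going by these compounds, how a piperidine carrying an amine or a carboxylic acid would behave at this position also remains open.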